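Trimming an Isopropyl to Methyl on a Receptor Agonist

The compounds below may be only part of what the source reports. "The series", "measured", "known", "first", "only" and "open" are said of these compounds alone.

Among the measured compounds shown here, compound 1 `CC#CC(CC(=O)O)c1ccc(OCc2ccc3nc(-c4ccc(C(C)C)cc4)cn3c2)cc1` is one of three compounds measured in an assay on isolated protein for agonist activity at Free fatty acid receptor 1 (Homo sapiens); on this read-out higher numbers stand for an effect only at larger amounts of compound and lower numbers for an effect already at smaller amounts. In this assay compound 1 gives 528 nM, the second highest of the three numbers. Compound 2 `CC#CC(CC(=O)O)c1ccc(OCc2ccn3cc(-c4ccc(C)cc4C)nc3c2)cc1` gives 503 nM, a value within the scatter of compound 1, while compound 3 `CC#CC(CC(=O)O)c1ccc(OCc2ccn3cc(-c4ccccc4)nc3c2)cc1` gives 1260 nM. For the measured compounds named here, the only single-point step among them, a 2.5-fold higher number from compound 2 to compound 3 (0.40 log units; beyond the scatter), came from phenyl replacing 2,4-dimethylphenyl on an aromatic carbon. Compound 4 `CC#CC(CC(=O)O)c1ccc(OCc2ccc3nc(-c4ccc(C)cc4)cn3c2)cc1` differs from compound 1 by methyl in place of isopropyl on an aromatic carbon. That change shrinks a substituent on a phenyl ring rather than removing it entirely, a lesser version of the earlier step. Compound 4 is therefore expected to show a small rise, near the edge of the scatter, as a 1.3-fold higher number from compound 1 to compound 4 (0.12 log units; within the scatter). Compound 4 is estimated at 700 nM, within 350 nM to 1400 nM.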

Compound 4, half-maximal effective concentration: 507 nM
Beside the measured number, compound 4's estimate is 1.4-fold (0.14 log units) above it; low and high end bracket the measured number.
By their numbers in this assay, from the lowest: compounds 2, 4 and 1 (each within the scatter of the next); then compound 3.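

Replacing isopropyl with methyl gives a 1.0-fold lower number from compound 1 to compound 4 (0.02 log units; within the scatter) in this assay, so this read-out does not separate 4-isopropylphenyl from 4-methylphenyl on the core of compound 1. At this position, para to a large group, the larger and the smaller of these two carbon groups give matching results. No available evidence explains this match. The compounds shown leave open whether a bare phenyl on this same core would hold the value, and what a methoxy group or an amine at this position would do.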